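Removing tert-butoxycarbonyl from compound 2

This account rests on a few compounds, and the source may have more. Where it says the series, first, only, none or still open, it means among the compounds named here.

In a physicochemical assay for solubility (on this read-out higher numbers stand for higher solubility and lower numbers for lower solubility), compound 1 `CN(C)c1ccc(C(=O)N2CCC(NS(=O)(=O)c3cc(S(=O)(=O)c4ccccc4)ccc3C(F)(F)F)CC2)cn1` gives 12500 nM and compound 2 `CC(C)(C)OC(=O)N1CCC(C(=O)N2CCC(NS(=O)(=O)c3cc(S(=O)(=O)c4ccccc4)ccc3C(F)(F)F)CC2)CC1` gives 25000 nM. Among the compounds with values here, these two values lie within the usual scatter of each other, so compound 2 is not separated from compound 1 on the numbers so far. Compound 3 `O=C(C1CCNCC1)N1CCC(NS(=O)(=O)c2cc(S(=O)(=O)c3ccccc3)ccc2C(F)(F)F)CC1` carries hydrogen in place of tert-butoxycarbonyl on an amine nitrogen in a ring. Within the data shown here, no measured pair shows this change, so its size remains a judgement. A moderate upward move beyond the scatter is expected in this assay, with an estimated size of a 2.4-fold higher number from compound 2 to compound 3 (0.38 log units; beyond the scatter). Compound 3 is expected at 60000 nM, with an estimated range of 25000 nM to 150000 nM.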

Compound 3, solubility: 100000 nM
Compound 3: middle estimate off by 1.7-fold (0.22 log units), on the low side; the measured number falls inside the stated range.
By their numbers in this assay, from the lowest: compounds 1 and 2 (each within the scatter of the next); then compound 3.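

In this assay, hydrogen in place of tert-butoxycarbonyl on an amine nitrogen in a ring gives a 4.0-fold higher number from compound 2 to compound 3 (0.60 log units; beyond the scatter) and so yields a separation that compound 1 and compound 2 did not show. Piperidin-4-yl in place of 6-(dimethylamino)pyridin-3-yl on a carbonyl carbon gives an 8.0-fold higher number from compound 1 to compound 3 (0.90 log units; beyond the scatter) and places compound 3 above both earlier compounds. No measurement at hand speaks to the cause of either step. Open, as far as these compounds go, is how a small group on this nitrogen, such as methyl or acetyl, would compare with hydrogen in compound 3.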